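The source may hold more compounds than are shown below. What is called first, only, known or untested is meant among the compounds shown, and "the series" means these compounds.

Measured compounds:
compound 1 `N=C(N)c1ccc(-c2ccc(-c3cc(Cl)cc(Cl)c3)s2)cc1`: 284 nM
compound 2 `N=C(N)c1ccc(-c2ccc(-c3ccc(F)cc3)s2)cc1`: 307 nM
compound 3 `N=C(N)c1ccc(-c2ccc(-c3ccc(Cl)cc3)s2)cc1F`: 218 nM

In a functional assay on SR cells (Homo sapiens) for inhibition, read by sulforhodamine B assay, with a stated time of 48 h (a lower number here means a stronger inhibitor of growth, a higher number a weaker inhibitor of growth), compound 3 gives the lowest number of the three, yet its gaps to compound 1 and to compound 2 both lie within the usual scatter, so nothing sets it apart from them. Compound 4 `COc1ccc(-c2ccc(-c3ccc(C(=N)N)c(F)c3)s2)cc1` has not been measured in this assay. It differs from compound 3 in one place: methoxy in place of chloro on an aromatic carbon. Within the data shown here, no measured pair shows this change, so its effect is unknown from these data alone. Given that the three measured compounds sit close together, the step of a 1.4-fold higher number from compound 3 to compound 4 (0.14 log units; within the scatter) is expected to be small and not clearly beyond the scatter. For compound 4 the expected value in this assay is 300 nM, with a range from 120 nM to 750 nM.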

Compound 4, concentration for 50% growth inhibition: 3170 nM
Estimate against measurement, compound 4: 11-fold (1.02 log units) below; the whole stated range lies below it.
By their numbers in this assay, from the lowest: compounds 3, 1 and 2 (each within the scatter of the next); then compound 4.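

In this assay, methoxy in place of chloro on an aromatic carbon, para to a large group, gives a 15-fold higher number from compound 3 to compound 4 (1.16 log units; beyond the scatter). The earlier compounds shown here offered no step between them and so showed nothing about this position; this single change now shows that it is not indifferent to what it carries. No measurement shown bears on why the step is so large.

Only this one replacement of chloro is shown. From the compounds shown here alone, whether a hydroxyl, a methyl or an amine at this position would behave like chloro or like methoxy remains open.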